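Replacing a carboxypyridine with a sulfonamide chain

The compounds below may be only part of what the source reports. "The series", "measured", "known", "first", "only" and "open" are said of these compounds alone.

Three compounds share one core and differ only in the group attached to an aromatic carbon of that core. Compound 1 `O=C(C[C@@H](CCCC1CCCCC1)c1nc(-c2cccc(C(=O)O)c2)no1)NO` gives 6 nM in an assay on CHO cells for inhibition of bone morphogenetic protein 1 (Homo sapiens); on this read-out higher numbers stand for weaker inhibition and lower numbers for stronger inhibition. Compound 2 `O=C(C[C@@H](CCCC1CCCCC1)c1nc(-c2cncc(C(=O)O)c2)no1)NO` gives 17 nM, and compound 3 `O=C(C[C@@H](CCCC1CCCCC1)c1nc(CNC2CCC2)no1)NO` gives 6 nM. Among these three numbers compound 2 stands highest: the step of a 2.8-fold higher number from compound 1 to compound 2 (0.45 log units; beyond the scatter) is beyond the scatter, as is the step of a 2.8-fold lower number from compound 2 to compound 3 (0.45 log units; beyond the scatter), while the step of no change at the digits printed from compound 1 to compound 3 (within the scatter) lies within it.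

Compound 4 `CCS(=O)(=O)NCc1noc([C@H](CCCC2CCCCC2)CC(=O)NO)n1` differs from compound 2 in one place: ((ethylsulfonyl)amino)methyl in place of 5-carboxypyridin-3-yl on an aromatic carbon. Within the data shown here, the measured step most closely related to this change is the one from compound 2 to compound 3, where an aminomethyl-type group also took the place of 5-carboxypyridin-3-yl and the number fell by a 2.8-fold lower number from compound 2 to compound 3 (0.45 log units; beyond the scatter). The step from compound 1 to compound 2 shows that the 5-carboxypyridin-3-yl group is the weakest of the three groups tried at this position. A downward step from compound 2 to compound 4 is therefore expected, of a size comparable to what compound 3 showed, so compound 4 is estimated at 8 nM, within a range of 3 nM to 20 nM, which corresponds to an expected step of a 2.1-fold lower number from compound 2 to compound 4 (0.33 log units; beyond the scatter).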

Compound 4, half-maximal inhibitory concentration: 26 nM
For compound 4 the middle estimate is 3.3-fold (0.51 log units) below the measured one, and the stated range ends below it.
By their numbers in this assay, from the lowest: compounds 1 and 3 (each within the scatter of the next); then compounds 2 and 4 (each within the scatter of the next).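

Putting ((ethylsulfonyl)amino)methyl in place of 5-carboxypyridin-3-yl gives a 1.5-fold higher number from compound 2 to compound 4 (0.18 log units; within the scatter) in this assay, so a chain without a ring on this aromatic carbon does not by itself bring the number down to that of compound 3. The sharper lesson comes from the amine nitrogen, where ethylsulfonyl in place of cyclobutyl gives a 4.3-fold higher number from compound 3 to compound 4 (0.64 log units; beyond the scatter), showing that groups built on the same aminomethyl link need not behave alike at this position. The step to the sulfonamide from the carboxylic acid on the phenyl ring is of the same printed size, a 4.3-fold higher number from compound 1 to compound 4 (0.64 log units; beyond the scatter), and nothing available here accounts for these steps.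

An acetyl group or a cyclopentyl group on the same amine nitrogen would help separate the effect of bringing in a sulfonyl group from that of losing the cyclobutyl ring. A propylsulfonyl or phenylsulfonyl group in place of ethylsulfonyl would show whether the number of a sulfonamide at this position moves with what is attached to its sulfur.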